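From compound 1 to its stereodefined form, compound 4

The compounds below may be only part of what the source reports. "The series", "measured", "known", "first", "only" and "open" are said of these compounds alone.

Among the measured compounds shown here, in a functional assay on the whole organism with Mus musculus as the target, in the writhing test (a higher number here means that more compound is needed for the effect, a lower number that less compound is needed), compound 1 `FC(F)(F)CCCSc1nsnc1C1CN2CCCC1C2` gives 0.1 mg/kg, the lowest of the numbers so far. The nearest number belongs to compound 3 `CC(C)CCCSc1nsnc1C1CN2CCCC1C2`, at 0.95 mg/kg. Compound 2 `CN1CCC=C(c2nsnc2SCCCc2ccccc2)C1` reads > 10 mg/kg, which is a limit of the assay and not a number.

Compound 4 `FC(F)(F)CCCSc1nsnc1[C@@H]1CN2CCC[C@@H]1C2` is the next to be read in this assay. The change is the two compounds have the same atoms and bonds; at least one stereo element is drawn with a configuration in one of them and without one in the other: 2 of 3 stereo elements differ; a stereocentre at a saturated ring carbon is drawn without a configuration in compound 1 and S in compound 4; a stereocentre at a saturated ring carbon is drawn without a configuration in compound 1 and S in compound 4: the atoms and bonds stay the same, while stereocentres at saturated ring carbons are drawn without a configuration in compound 1 and S in compound 4.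

For the measured compounds named here, only one measured step is available, and it does not touch the stereocentres. With isopropyl in place of trifluoromethyl on a saturated chain carbon, three bonds along the chain from a sulfur, the reading moves by a 9.5-fold higher number from compound 1 to compound 3 (0.98 log units; beyond the scatter). This shows how far this assay can move within the series, but gives no direction for the present change. The expectation therefore stays anchored on compound 1 at 0.1 mg/kg, with no shift beyond the scatter and a wide margin on both sides. The expected change is no change at the digits printed from compound 1 to compound 4 (within the scatter). For compound 4 the estimated value is 0.1 mg/kg, with an expected range of 0.03 mg/kg to 0.5 mg/kg.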

Compound 4, dose for half-maximal effect: 0.35 mg/kg
Compound 4: the middle estimate sits 3.5-fold (0.54 log units) below what was measured; the range from low to high includes it.
By their numbers in this assay, from the lowest: compound 1; then compound 4; then compound 3. At a limit, above all of these: compound 2.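

In this assay, the reading moves with the atoms and bonds left unchanged, and the two stereocentres at saturated ring carbons, drawn as S in compound 4, are the only difference: a 3.5-fold higher number from compound 1 to compound 4 (0.54 log units; beyond the scatter). Among the compounds shown here, the earlier step, a 9.5-fold higher number from compound 1 to compound 3 (0.98 log units; beyond the scatter), concerned only the end of the sulfur-linked chain, so this is the first sign that the way the core is drawn in space also goes with a reading beyond the scatter. The shift can be tied to nothing other than stereochemistry, because no other difference separates this pair: the fact that one of compounds 1 and 4 is drawn with a defined configuration and the other without, at the place where they differ

The compounds shown do not say which configurations are present in compound 1, or how the other arrangements at these two ring carbons read, so it remains open whether any form reads lower than compound 1 or higher than compound 4. On these data alone, it is also open whether the effect of replacing trifluoromethyl on the chain, for instance by a nitrile or with a longer chain, holds on the stereodefined core of compound 4.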